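Swapping the Isobutyl Arm for a Methoxy Group

This account rests on a few compounds, and the source may have more. Where it says the series, first, only, none or still open, it means among the compounds named here.

Of the compounds shown here, three have been tested in an assay on HEK293 cells for agonist activity at transient receptor potential cation channel subfamily M member 8 (Homo sapiens), read by fluorescence and calcium flux, with a stated time of 15 min; a lower number here means that less compound is needed, a higher number that more compound is needed for the effect. Compound 1 `Cc1ccc(OCC(=O)N(Cc2cccs2)c2ccn(C)n2)cc1` gives 855 nM, compound 2 `Cc1ccc(OCC(=O)N(Cc2cccs2)CC(C)C)cc1` gives 900 nM, and compound 3 `CCN(Cc1cccs1)C(=O)c1cc2cc(C)ccc2o1`, whose core differs in more than one place from the other two, gives 120 nM. Compound 2 therefore has the highest number of the three, but its value and that of compound 1 are within the scatter of each other, while compound 3 sits clearly apart.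

Compound 4 `CON(Cc1cccs1)C(=O)COc1ccc(C)cc1` is not yet measured. It differs from compound 2 in one place: methoxy in place of isobutyl on an amide-type nitrogen. Among the compounds with values here, only one measured step changes the same amide-type nitrogen, and it shows a 1.1-fold higher number from compound 1 to compound 2 (0.02 log units; within the scatter); a group with a ring and a plain branched chain behaved alike there. Within the data shown here, a methoxy group is smaller still and carries an acceptor, and no measured pair tells how such a group behaves at this position.

On that basis compound 4 is expected to land near compound 2 in this assay, with a wide margin of uncertainty. The estimate for compound 4 is 1500 nM, with a plausible range from 500 nM to 5000 nM, which corresponds to an expected step of a 1.7-fold higher number from compound 2 to compound 4 (0.22 log units; within the scatter).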

Compound 4, half-maximal effective concentration: 10 nM
Compound 4: the middle estimate sits 150-fold (2.18 log units) above what was measured, outside the stated range (below it).
By their numbers in this assay, from the lowest: compound 4; then compound 3; then compounds 1 and 2 (each within the scatter of the next).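

In this assay the group on the amide-type nitrogen turns out to matter a great deal: methoxy in place of isobutyl gives (a 90-fold lower number from compound 2 to compound 4 (1.95 log units; beyond the scatter)), and methoxy in place of 1-methyl-1H-pyrazol-3-yl gives (an 86-fold lower number from compound 1 to compound 4 (1.93 log units; beyond the scatter)). Within the data shown here, the only earlier step at this nitrogen (a 1.1-fold higher number from compound 1 to compound 2 (0.02 log units; within the scatter)) made the position look insensitive, but that flat result now holds only for those two groups, not for the position as a whole. The change itself looks modest on paper, with methoxy bringing 2 heavy atoms and 1 hydrogen-bond acceptor where isobutyl has 4 heavy atoms and 0 hydrogen-bond acceptors, so a swap of this size can move the number far more than the earlier pair suggested.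

No measurement at hand explains why methoxy stands so far from the other two groups. The compounds shown also cannot separate the effect of the oxygen from that of the shorter group, and an ethoxy group or a hydroxyl group on the same nitrogen would be needed to begin telling the two apart.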